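This account rests on a few compounds, and the source may have more. Where it says the series, first, only, none or still open, it means among the compounds named here.

Compound 2 `COc1ccccc1-c1cc(CN(C)C)ccc1Cl` gives 220 nM in an assay on isolated protein for binding affinity to 5-hydroxytryptamine receptor 5A (Homo sapiens); on this read-out higher numbers stand for weaker inhibition and lower numbers for stronger inhibition. For the measured compounds named here, compound 1 `CNCc1ccc(Cl)c(-c2ccccc2OC)c1` gives 420 nM in this assay, and the step of a 1.9-fold lower number from compound 1 to compound 2 (0.28 log units; within the scatter) is the only measured step, so compound 2 sits within the scatter of compound 1. Compound 3 `CCCCNCc1ccc(Cl)c(-c2ccccc2OC)c1` differs from compound 2 by butylamino in place of dimethylamino on a saturated chain carbon bound to an aromatic carbon. Going by the values given here, the one measured step touches the same amine but exchanges only hydrogen for methyl and stayed within the scatter; nothing measured covers a longer chain. The expected step is a 1.4-fold higher number from compound 2 to compound 3 (0.13 log units; within the scatter), small and with no clear direction. Compound 3 is estimated at 300 nM, range 100 nM to 900 nM.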

Compound 3, inhibition constant: 360 nM
Compound 3: the middle estimate sits 1.2-fold (0.08 log units) below what was measured; the measured number falls inside the stated range.
By their numbers in this assay, from the lowest: compounds 2, 3 and 1 (each within the scatter of the next).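

In this assay, the amine carbon tolerates a much larger substituent than the earlier hydrogen-to-methyl exchange could show: butylamino replacing dimethylamino gives a 1.6-fold higher number from compound 2 to compound 3 (0.21 log units; within the scatter). Extending the chain by propyl gives a 1.2-fold lower number from compound 1 to compound 3 (0.07 log units; within the scatter), so across these three compounds neither the longer chain nor the hydrogen-bond donor that butylamino brings and dimethylamino lacks separates the values beyond the scatter. From the compounds shown here alone, whether a longer chain such as octyl, a branched group such as isopropyl, or a piperidine would stay within the scatter remains open. No supporting evidence on this result is available.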